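Series notes: chloro to methyl on the fused ring

The source may hold more compounds than are shown below. What is called first, only, known or untested is meant among the compounds shown, and "the series" means these compounds.

Three amides of a shared core have been measured in a functional assay on A549 cells (Homo sapiens) for cytotoxicity, read by MTT assay, with a stated time of 72 h; on this read-out higher numbers stand for weaker inhibition and lower numbers for stronger inhibition. Compound 1 `Cc1ccc2nc(NC(=O)c3cn(-c4ccccc4)nc3-c3ccc(Cl)cc3)sc2c1` gives 18600 nM. Compound 2 `COc1ccc(-c2nn(-c3ccccc3)cc2C(=O)Nc2nc3ccc(F)cc3s2)cc1` gives 7560 nM, and compound 3 `COc1ccc(-c2nn(-c3ccccc3)cc2C(=O)Nc2nc3ccc(Cl)cc3s2)cc1` gives 4710 nM, the smallest number of the three; the gap to compound 2 lies within the scatter, so only compound 1 stands apart from compound 3. One step between measured compounds changes a single place: a 1.6-fold lower number from compound 2 to compound 3 (0.21 log units; within the scatter).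

The next compound, compound 4 `COc1ccc(-c2nn(-c3ccccc3)cc2C(=O)Nc2nc3ccc(C)cc3s2)cc1`, changes compound 3 by methyl in place of chloro on an aromatic carbon. Going by the values given here, the step from compound 2 to compound 3 is the only single-place step recorded at this position, and it stayed within the scatter; it concerns fluoro against chloro and so bears only loosely on an exchange of chloro for methyl. Among the compounds with values here, compound 1 carries the same methyl on the same fused ring, but it also differs from compound 3 at a second place, so the two values show only that compound 1 sits higher than compound 3 and no step between them is recorded. On this basis the step in this assay is expected to be small, with a lean towards a somewhat higher number. The step expected is a 1.4-fold higher number from compound 3 to compound 4 (0.14 log units; within the scatter). Compound 4 is estimated at 6500 nM, with a range from 3000 nM to 14000 nM.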

Compound 4, half-maximal inhibitory concentration: 27700 nM
Compound 4: the middle estimate sits 4.3-fold (0.63 log units) below what was measured, and the stated range ends below it.
By their numbers in this assay, from the lowest: compounds 3 and 2 (each within the scatter of the next); then compounds 1 and 4 (each within the scatter of the next).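

In this assay the exchange of 6-chloro-1,3-benzothiazol-2-yl for 6-methyl-1,3-benzothiazol-2-yl is not neutral (a 5.9-fold higher number from compound 3 to compound 4 (0.77 log units; beyond the scatter)), so this position responds to a change that the earlier single-place step did not reveal. Methyl in place of fluoro at the same carbon also goes beyond the scatter (a 3.7-fold higher number from compound 2 to compound 4 (0.56 log units; beyond the scatter)), while fluoro and chloro remain within it of each other (a 1.6-fold lower number from compound 2 to compound 3 (0.21 log units; within the scatter)); among these three compounds, the two halogens therefore group together and methyl stands apart. With the methyl held in place, methoxy in place of chloro on the other aromatic carbon makes no readable difference (a 1.5-fold higher number from compound 1 to compound 4 (0.17 log units; within the scatter)), and no measurement at hand accounts for any of these steps.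

Going by these compounds, whether the higher number belongs to methyl alone or extends to other groups at this carbon stays open, for instance an ethyl, a methoxy, a trifluoromethyl or an amine. Also open, on these data alone, is whether the chloro against methyl step keeps its size when the chloro replaces the methoxy on the other aromatic ring.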